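From nitro to trifluoromethyl on compound 2

This account rests on a few compounds, and the source may have more. Where it says the series, first, only, none or still open, it means among the compounds named here.

Compound 1 `c1ccc(COc2ccccc2Nc2ncnc3cc4c(cc23)OCCOCCO4)cc1` gives > 100000 nM (a limit of the assay)
Compound 2 `O=[N+]([O-])c1ccc(COc2ccc(Nc3ncnc4cc5c(cc34)OCCOCCO5)cc2)cc1` gives 39700 nM
Compound 3 `FC(F)(F)c1ccc(COc2cccc(Nc3ncnc4cc5c(cc34)OCCOCCOCCOCCO5)c2)cc1` gives 8480 nM

All three compounds were tested in a functional assay on MCF7 cells (Homo sapiens) for antiproliferative activity, read by MTT assay, with a stated time of 72 h (a lower number here means a stronger inhibitor, a higher number a weaker inhibitor), and the entry for compound 1 is a limit, not a number. Of the two actual numbers, compound 2 holds the higher at 39700 nM, and compound 3 gives 8480 nM. The gap between these two lies beyond the scatter on this scale.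

Compound 4 `FC(F)(F)c1ccc(COc2ccc(Nc3ncnc4cc5c(cc34)OCCOCCO5)cc2)cc1` departs from compound 2 in one place: trifluoromethyl in place of nitro on an aromatic carbon, para to a large group (trifluoromethyl in place of nitro on an aromatic carbon). For the measured compounds named here, no measured pair isolates this change. Compound 3 also carries a 4-(trifluoromethyl)benzyl group and gives 8480 nM but differs in other ways, so it offers only a weak hint. A modest move toward a lower number is expected, with a 1.6-fold lower number from compound 2 to compound 4 (0.20 log units; within the scatter) in this assay possibly staying close to the scatter. The estimate for compound 4 is 25000 nM (expected range 7000 nM to 90000 nM).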

Compound 4, half-maximal inhibitory concentration: > 100000 nM
Compound 4: only a limit was reported (the forecaster's own chance of this, stated with the estimate: 20%); at least 4.0-fold (0.60 log units) between middle value and limit.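

For the compounds shown here, exchanging 4-nitrobenzyl for 4-(trifluoromethyl)benzyl is the only change here isolated in one place, and in this assay it gives an at least 2.5-fold higher number from compound 2 to compound 4 (0.40 log units; beyond the scatter). At this position, on the aromatic carbon para to a large group, nitro therefore goes with the lower number of the pair, so trifluoromethyl is no neutral swap for it in this assay. The full size of the step stays unknown because compound 4 gives only a limit, not a number: the limit of > 100000 nM in this assay, at which 2 of the 4 values shown sit.

The compounds shown leave open whether another group at this position, such as an amine, a carboxylic acid or a nitrile, would lower the number of compound 2 or raise it. Going by these compounds alone, whether the same exchange would act alike on the core of compound 3 also stays open, since no pair isolates it there.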